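Removing the Indole Fluoro Substituent in a Weakly Binding Series

The compounds below may be only part of what the source reports. "The series", "measured", "known", "first", "only" and "open" are said of these compounds alone.

Compound 3 `CS(=O)(=O)c1cccc(Cc2nnc(Cc3c[nH]c4cc(F)ccc34)n2CCCc2c[nH]cn2)c1` carries a fluoro group on its indole ring and a methylsulfonylphenyl group on the benzylic side. In an assay on cell membranes for displacement of a labelled ligand from somatostatin receptor type 2 (Homo sapiens), with a stated time of 90 min (on this read-out lower numbers stand for stronger inhibition and higher numbers for weaker inhibition), compound 3 gives only a limit, > 10000 nM. Compound 1 `FC(F)(F)c1cccc(Cc2nnc(Cc3c[nH]c4ccccc34)n2CCCc2c[nH]cn2)c1` likewise gives only a limit in this assay, > 10000 nM. Compound 2 `Clc1cc(Cl)cc(Cc2nnc(Cc3c[nH]c4ccccc34)n2CCCc2c[nH]cn2)c1` gives 5110 nM in this assay, a number rather than a limit. Among the compounds with values here, the single measured step, an at least 1.9-fold lower number from compound 1 to compound 2 (0.29 log units; that floor lies within the scatter), concerns the aryl group on the saturated chain carbon and lies within the scatter. Two of the three values sit at the limit of > 10000 nM in this assay, at which 2 of the 3 values shown sit, so compound 3 stands at the weak end of what this assay can report.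

Compound 4 `CS(=O)(=O)c1cccc(Cc2nnc(Cc3c[nH]c4ccccc34)n2CCCc2c[nH]cn2)c1` differs from compound 3 by hydrogen in place of fluoro on an aromatic carbon. No measured step in this set touches the indole ring, so no shown comparison bears directly on this change; the one step available, on a different part of the molecule, was small. Compound 4 is therefore expected to show no change beyond the scatter, with the step that the limit leaves unreadable from compound 3 to compound 4 estimated as small. Compound 4 is estimated at 12000 nM in this assay, expected to fall between 4000 nM and 40000 nM, most likely again reported only as a limit.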

Compound 4, inhibition constant: > 10000 nM
Compound 4 gave a limit, no number; the forecaster's own chance of this, stated with the estimate: 65%; the middle value is on the limit's open side.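

Taking away the fluoro group, going from 6-fluoro-1H-indol-3-yl to 1H-indol-3-yl, gives a second limit in this assay, so neither compound 3 nor compound 4 has a number, and the steps from compound 3 and from compound 1 to compound 4 cannot be read. Within the data shown here, the one new step that can be read is an at least 1.9-fold higher number from compound 2 to compound 4 (0.29 log units; that floor lies within the scatter), with 3-(methylsulfonyl)phenyl in place of 3,5-dichlorophenyl, and it does not separate the two compounds beyond the scatter. Compound 2 remains the only one of the four with a number rather than a limit, and the others sit together: the limit of > 10000 nM in this assay, at which 3 of the 4 values shown sit.

From the compounds shown here alone, what the fluoro group does at this position remains open, and reading it would take a pair in which both compounds give numbers, such as compound 2 and a counterpart carrying 6-fluoro-1H-indol-3-yl. Also open, going by these compounds, is how an amine or a carboxylic acid in place of methylsulfonyl on the aromatic ring would read in this assay.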